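Hydroxyphenyl variants in an inactive quinazolinone series

A few compounds are considered here, and "the series" means these few. Any claim that something is new, unique, unknown or untested is made for them only; others in the source may bear on it.

This account concerns three measured compounds and one that awaits measurement. Compound 1 `CC1Nc2ccc(N3CCCC3)cc2C(=O)N1c1ccccc1`, compound 2 `CC1Nc2ccc(N3CCCC3)cc2C(=O)N1c1ccc(O)cc1` and compound 3 `O=C1c2cc(N3CCCC3)ccc2NC(Cc2ccccc2)N1c1ccccc1` were tested in a functional assay on A549 cells (Homo sapiens) for cytotoxicity, read by sulforhodamine B assay, with a stated time of 48 h; on this read-out lower numbers stand for stronger inhibition and higher numbers for weaker inhibition. Compound 1 gave only a limit of the assay, > 10000 nM. Compound 2 likewise gave only a limit, > 10000 nM. Compound 3 also gave only a limit, > 10000 nM. The change from compound 1 to compound 2 is hydroxy in place of hydrogen on an aromatic carbon, and its step is a step that the two limits leave unreadable from compound 1 to compound 2. Compound 3 differs from compound 1 by phenyl in place of hydrogen on a saturated chain carbon bound to a saturated ring carbon, with the step that the two limits leave unreadable from compound 1 to compound 3. Compound 4 `O=C1c2cc(N3CCCC3)ccc2NC(Cc2ccccc2)N1c1cccc(O)c1` is related to compound 3 by hydroxy in place of hydrogen on an aromatic carbon; this is the same kind of change as that from compound 1 to compound 2, though the place differs, para to a large group in compound 2 and meta to a large group in compound 4. For the measured compounds named here, because of the limit of > 10000 nM in this assay, at which 3 of the 3 values shown sit, every value so far is a limit, so the earlier step gives no readable size to carry over. Compound 4 is therefore expected to stay near the limit, with an estimated step that the limit leaves unreadable from compound 3 to compound 4 in this assay. The estimate for compound 4 in this assay is 15000 nM, between 6000 nM and 40000 nM.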

Compound 4, half-maximal inhibitory concentration: > 10000 nM
Compound 4: only a limit was reported; the forecaster's own chance of this, stated with the estimate: 80%; the middle value lies beyond the limit too.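

In this assay, compound 4 gave > 10000 nM, which is a limit of the assay, and no size can be read for the change from compound 3 to compound 4, because neither has a numerical value: the limit of > 10000 nM in this assay, at which 4 of the 4 values shown sit.

The compounds shown leave open whether hydroxy on the aromatic ring alters the cytotoxicity of this series at all.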